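A few compounds are considered here, and "the series" means these few. Any claim that something is new, unique, unknown or untested is made for them only; others in the source may bear on it.

In a functional assay on Jurkat cells (Homo sapiens) for inhibition, read by CCK-8 assay, with a stated time of 48 h (a lower number here means a stronger inhibitor of growth, a higher number a weaker inhibitor of growth), three compounds built on a shared core have been measured. Compound 1 `Cc1ccccc1Nc1nc(Nc2ccc(N3CCN(C)CC3)cn2)ncc1Cl` gives 8080 nM, compound 2 `COc1ccccc1CNc1nc(Nc2ccc(N3CCN(C)CC3)cn2)ncc1Cl` gives 10800 nM, and compound 3 `CC(C)c1ccccc1Nc1nc(Nc2ccc(N3CCN(C)CC3)cn2)ncc1Cl` gives 5140 nM. Compound 3 therefore sits at the low end of a narrow range, a place it shares with compound 1. The two gaps that touch it are a 1.6-fold lower number from compound 1 to compound 3 (0.20 log units; within the scatter) and a 2.1-fold lower number from compound 2 to compound 3 (0.32 log units; beyond the scatter).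

The next compound, compound 4 `COc1ccc(Nc2nc(Nc3ccc(N4CCN(C)CC4)cn3)ncc2Cl)cc1`, has not yet been measured. It carries 4-methoxyphenyl in place of 2-isopropylphenyl on a nitrogen on an aromatic ring. Going by the values given here, no measured compound carries 4-methoxyphenyl, so the data offer no direct guide to this group. The nearest evidence is how little the number has moved when the group on that nitrogen was changed, as in a 1.3-fold higher number from compound 1 to compound 2 (0.13 log units; within the scatter) and the two gaps above. The expected step is therefore small, a 1.6-fold higher number from compound 3 to compound 4 (0.19 log units; within the scatter), and no larger than those already seen. Compound 4 is estimated at 8000 nM, with an expected range of 3500 nM to 18000 nM.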

Compound 4, concentration for 50% growth inhibition: 11200 nM
Estimate against measurement, compound 4: 1.4-fold (0.15 log units) below; measured number inside the range.
By their numbers in this assay, from the lowest: compounds 3, 1, 2 and 4 (each within the scatter of the next, the first and the last beyond it).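

In this assay, going by these compounds alone, the change to 4-methoxyphenyl gives a 2.2-fold higher number from compound 3 to compound 4 (0.34 log units; beyond the scatter) and is the first step between two phenyl groups on this nitrogen to pass the scatter. The new group does not stand apart from the others, with a 1.0-fold higher number from compound 2 to compound 4 (0.02 log units; within the scatter) and a 1.4-fold higher number from compound 1 to compound 4 (0.14 log units; within the scatter) both within the scatter, so compound 3 separates from compound 2 and compound 4 but not from compound 1. Nothing measured here accounts for this small shift at the nitrogen.

This step changes both the group on the phenyl ring and its numbered place at once, and the two effects cannot be told apart. On these data alone, it also remains open whether an amine or a carboxylic acid on that phenyl ring would move the number further than these neutral groups have.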